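This account rests on a few compounds, and the source may have more. Where it says the series, first, only, none or still open, it means among the compounds named here.

Three compounds have been measured in a functional assay on MCF7 cells (Homo sapiens) for antiproliferative activity, read by MTT assay, with a stated time of 24 h, tested at 12.5 uM; on this read-out higher numbers stand for a weaker effect at the one concentration tested and lower numbers for a stronger effect:

Compound 1 `OCC(O)Cn1nc2c(Br)c(Br)c(Br)c(Br)c2n1` gives 145%.
Compound 2 `OC(CCn1nc2c(Br)c(Br)c(Br)c(Br)c2n1)c1ccc(Br)cc1` gives 82%.
Compound 3 `CC(O)CCn1nc2c(Br)c(Br)c(Br)c(Br)c2n1` gives 99%.

Compound 3 stands second highest of the three numbers, with compound 2 below it and compound 1 above it, and both gaps lie beyond the scatter. Compound 4 `OC(CCn1nc2c(Br)c(Br)c(Br)c(Br)c2n1)c1ccc(F)cc1` differs from compound 3 by 4-fluorophenyl in place of methyl on a saturated chain carbon bound to an oxygen on a saturated carbon and a saturated chain carbon. The step that bears most directly on this change is a number 17 percentage points higher from compound 2 to compound 3 (beyond the scatter), which ran in the opposite direction to the change now made with a different halogen on the ring; a number 46 percentage points lower from compound 1 to compound 3 (beyond the scatter) concerns another part of the chain and is less informative here. A downward step of similar size is therefore expected. Compound 4 is estimated to give 85%, with a range of 65% to 105%, which is expected to mean a number 14 percentage points lower from compound 3 to compound 4 (beyond the scatter).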

Compound 4, a percentage reported as activity, at one concentration (the size of the read-out at that concentration, not a potency): 116%
Estimate against measurement, compound 4: 31 percentage points below; measured number above the stated range.
By their numbers in this assay, from the lowest: compound 2; then compound 3; then compound 4; then compound 1.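

In this assay a phenyl ring at this carbon does not by itself lower the number: with a number 17 percentage points higher from compound 3 to compound 4 (beyond the scatter) the 4-fluorophenyl group moves it the opposite way from the 4-bromophenyl group. The halogen on the ring therefore decides the direction of the change here, and with a number 34 percentage points higher from compound 2 to compound 4 (beyond the scatter) swapping it matters more than replacing methyl with either ring. Whether an amine on the ring or a longer chain in place of the methyl would raise or lower the number stays open, and nothing available accounts for the gap between the two halogens.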